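From isopropylcarbonyl to isopropylcarbamoyl: an expected stability

A few compounds are considered here, and "the series" means these few. Any claim that something is new, unique, unknown or untested is made for them only; others in the source may bear on it.

Measured so far in an ADME assay on microsomes from liver (Rattus norvegicus) for metabolic stability, with a stated time of 10 min; on this read-out higher numbers stand for a more stable compound and lower numbers for a less stable compound:
Compound 1 `CCCCCNc1nc(Nc2ccc([N+](=O)[O-])cc2)nc(OCC(F)(F)F)n1`: 35%
Compound 2 `CC(C)(C)NC(=O)NCCS(=O)(=O)NC(=O)c1ccc(Nc2nc(NC3(c4ccc(Cl)cc4)CC3)nc(OCC(F)(F)F)n2)cc1`: 93%
Compound 3 `CC(C)C(=O)NCCS(=O)(=O)NC(=O)c1ccc(Nc2nc(NC3(c4ccc(Cl)cc4)CC3)nc(OCC(F)(F)F)n2)cc1`: 84%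

Compound 3 stands second of the three numbers in this assay; its nearest neighbour is compound 2, which lies within the scatter of it, while compound 1 sits far below, beyond the scatter. Going by the values given here, only one measured step bears on the change considered here, namely a number 9 percentage points lower from compound 2 to compound 3 (within the scatter), and that step stayed within the scatter.

Compound 4 `CC(C)NC(=O)NCCS(=O)(=O)NC(=O)c1ccc(Nc2nc(NC3(c4ccc(Cl)cc4)CC3)nc(OCC(F)(F)F)n2)cc1` differs from compound 3 by isopropylamino in place of isopropyl on a carbonyl carbon. With this change compound 4 carries a urea-type arrangement on that carbonyl carbon, as compound 2 does with its (tert-butyl)amino group. Because compound 2 gave 93% and the step of a number 9 percentage points lower from compound 2 to compound 3 (within the scatter) was within the scatter, the expected step of a number 4 percentage points higher from compound 3 to compound 4 (within the scatter) is small, pointing if anywhere slightly upward, and is not expected to exceed the scatter. Compound 4 is therefore estimated at 88% in this assay, with an expected range from 76% to 97%.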

Compound 4, percent of the compound remaining: 97%
For compound 4 the middle estimate is 9 percentage points below the measured one; the measured number falls inside the stated range.
By their numbers in this assay, from the lowest: compound 1; then compounds 3, 2 and 4 (each within the scatter of the next, the first and the last beyond it).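

In this assay the change at this carbonyl carbon gives a number 13 percentage points higher from compound 3 to compound 4 (beyond the scatter), a modest step and the first here at this position to lie beyond the scatter. With (tert-butyl)amino and isopropylamino on the same carbonyl carbon, the values show a number 4 percentage points higher from compound 2 to compound 4 (within the scatter), so this read-out does not separate these two groups, while isopropyl stands apart from isopropylamino. Nothing available here accounts for the step from isopropyl to isopropylamino.

The compounds shown leave open how a dimethylamino group or a methoxy group would read on this carbonyl carbon, and whether a longer chain such as n-butylamino would stay with the two amino-bearing compounds. They also leave open whether the step from isopropyl to isopropylamino would recur on another core.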